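A few compounds are considered here, and "the series" means these few. Any claim that something is new, unique, unknown or untested is made for them only; others in the source may bear on it.

Compound 3 `CNS(=O)(=O)NC[C@@H]1CCCc2cc(S(=O)(=O)c3cccc(F)c3)ccc21` stands second highest of the three numbers measured in an assay on isolated protein for displacement of a labelled ligand from 5-hydroxytryptamine receptor 6 (Homo sapiens) (a higher number here means a weaker inhibitor, a lower number a stronger inhibitor), where compound 3 gives 1 nM. Compound 1 `NC[C@@H]1CCCc2cc(S(=O)(=O)c3cccc(O)c3)ccc21` gives 0.251 nM in this assay, and compound 2 `CS(=O)(=O)c1cccc(S(=O)(=O)c2ccc3c(c2)CCC[C@H]3CN)c1` gives 3.98 nM. Among the measured compounds shown here, the only single-place step among the measured compounds, a 16-fold higher number from compound 1 to compound 2 (1.20 log units; beyond the scatter), exchanges a group on an aromatic carbon, not on the amine nitrogen. Compound 4 `O=C(NC[C@@H]1CCCc2cc(S(=O)(=O)c3cccc(F)c3)ccc21)c1ncc[nH]1` has not yet been measured in this assay. It differs from compound 3 by (1H-imidazol-2-yl)carbonyl in place of methylsulfamoyl on an amine nitrogen. For the measured compounds named here, no measured step alters the substituent on the amine nitrogen, so the step from compound 3 to compound 4 has no direct precedent here; compound 1 carries an unsubstituted amine, but it also differs from compound 3 on the aromatic ring, so its value speaks to this change only loosely. The expectation is therefore a step of about a 2.0-fold higher number from compound 3 to compound 4 (0.30 log units; within the scatter), near the scatter and with wide uncertainty. Compound 4 is accordingly expected to give roughly 2 nM in this assay, with a range of 0.5 nM to 8 nM.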

Compound 4, inhibition constant: 15.9 nM
Estimate against measurement, compound 4: 8.0-fold (0.90 log units) below, and the stated range ends below it.
By their numbers in this assay, from the lowest: compound 1; then compound 3; then compound 2; then compound 4.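

The substituent on the amine nitrogen turns out to matter in this assay: with the rest of the molecule unchanged, (1H-imidazol-2-yl)carbonyl in place of methylsulfamoyl gives a 16-fold higher number from compound 3 to compound 4 (1.20 log units; beyond the scatter) as a large step. Both groups count the same hydrogen-bond donors and acceptors and carry no net charge, so these counts alone do not track the difference. Nothing at hand accounts for the size of this step.

The compounds shown leave open whether the step follows the carbonyl or the imidazole ring, which an acetyl or a benzoyl group on the same amine nitrogen would separate. Going by these compounds, it also remains open how an unsubstituted amine on the core of compound 3 would stand against both substituents.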